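Three amine side chains on a shared core

This account rests on a few compounds, and the source may have more. Where it says the series, first, only, none or still open, it means among the compounds named here.

Compound 1 `CCN(CC)CCn1cccc1/C=N/NC(=O)Nc1ccc(Oc2ccnc3[nH]ccc23)cc1`: 3570 nM
Compound 2 `CN(C)CCCn1cccc1/C=N/NC(=O)Nc1ccc(Oc2ccnc3[nH]ccc23)cc1`: 2660 nM
Compound 3 `CN1CCN(CCCn2cccc2/C=N/NC(=O)Nc2ccc(Oc3ccnc4[nH]ccc34)cc2)CC1`: 1640 nM

These three values all come from a functional assay on A549 cells (Homo sapiens) for antiproliferative activity, read by MTT assay, with a stated time of 72 h (a higher number here means a weaker inhibitor, a lower number a stronger inhibitor), where the compounds differ only in the amine-bearing chain on the shared core. Compound 3 stands at 1640 nM. Reaching it from the other two gives a 2.2-fold lower number from compound 1 to compound 3 (0.34 log units; beyond the scatter), a modest step, and a 1.6-fold lower number from compound 2 to compound 3 (0.21 log units; within the scatter). The remaining pair shows a 1.3-fold lower number from compound 1 to compound 2 (0.13 log units; within the scatter).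

The next structure is compound 4 `O=C(N/N=C/c1cccn1CCCN1CCCC1)Nc1ccc(Oc2ccnc3[nH]ccc23)cc1`. Going by the values given here, its single change is pyrrolidin-1-yl in place of 4-methylpiperazin-1-yl on a saturated chain carbon, three bonds along the chain from an aromatic nitrogen. Put another way, 3-(4-methylpiperazin-1-yl)propyl gives way to 3-(pyrrolidin-1-yl)propyl.

Among the compounds with values here, the closest precedent is the swap at this same place, which gave a 1.6-fold lower number from compound 2 to compound 3 (0.21 log units; within the scatter). Within the data shown here, the amine changes measured so far have therefore moved the number only a little, and only one of the three steps clears the scatter. Among the measured compounds shown here, no compound with pyrrolidin-1-yl has been measured, so the direction is uncertain, and no step beyond the scatter is expected in this assay. The expected step is a 1.3-fold higher number from compound 3 to compound 4 (0.11 log units; within the scatter). For compound 4 the estimated value is 2100 nM, with an expected range from 1000 nM to 4200 nM.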

Compound 4, half-maximal inhibitory concentration: 1300 nM
Compound 4: middle estimate off by 1.6-fold (0.21 log units), on the high side; the measured number falls inside the stated range.
By their numbers in this assay, from the lowest: compounds 4, 3, 2 and 1 (each within the scatter of the next, the first and the last beyond it).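

Swapping the six-membered 4-methylpiperazin-1-yl ring for the five-membered pyrrolidin-1-yl ring, which has one ring nitrogen rather than two, leaves the result in this assay unresolved (a 1.3-fold lower number from compound 3 to compound 4 (0.10 log units; within the scatter)), so at this place on the chain the second ring nitrogen is not needed to stay at this level. Going by these compounds alone, compound 4 also gives the first step beyond the scatter from the dimethylamino group on this same propyl chain (a 2.0-fold lower number from compound 2 to compound 4 (0.31 log units; beyond the scatter)), whereas the step to compound 3 stayed within it. Its gap to the diethylamino compound is the widest in the set, though still modest (a 2.7-fold lower number from compound 1 to compound 4 (0.44 log units; beyond the scatter)), so the whole series spans only a narrow range.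

No independent data here explain why these amines differ or why the two ring amines sit level. Going by these compounds, it remains open whether other rings on the same propyl chain, such as piperidin-1-yl or morpholin-4-yl, would hold this level, and whether a longer chain, such as 4-(pyrrolidin-1-yl)butyl, would move the number beyond the scatter.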